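The source may hold more compounds than are shown below. What is called first, only, known or untested is meant among the compounds shown, and "the series" means these compounds.

Compound 1, `CN(C(=O)NC(=O)c1ccc(F)c(F)c1)c1nc(C(F)(F)F)c(C(=O)N/N=C/c2ccc(C(F)(F)F)cc2)s1`, gives 5.93 ug/mL in a functional assay on MCF7 cells (Homo sapiens) for inhibition, read by MTT assay, with a stated time of 72 h; on this read-out lower numbers stand for stronger inhibition and higher numbers for weaker inhibition. Compound 3, `CN(C(=O)NC(=O)c1ccccc1F)c1nc(C(F)(F)F)c(C(=O)N/N=C/c2ccccc2C(F)(F)F)s1`, gives 12.2 ug/mL. Compound 2, `CN(C(=O)NC(=O)c1ccc(C(F)(F)F)cc1)c1nc(C(F)(F)F)c(C(=O)N/N=C/c2ccc(C(F)(F)F)cc2)s1`, gives only a limit in this assay, > 100 ug/mL, sitting at the limit of > 100 ug/mL in this assay, at which 1 of the 3 values shown sits.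

Of the two numbers shown, compound 3 stands highest; compound 1 shows the lower number, a gap beyond the scatter. Compound 4, `CN(C(=O)NC(=O)c1ccccc1F)c1nc(C(F)(F)F)c(C(=O)N/N=C/c2ccc(C(F)(F)F)cc2)s1`, differs from compound 3 by 4-(trifluoromethyl)phenyl in place of 2-(trifluoromethyl)phenyl on a carbon with a double bond to nitrogen. Going by the values given here, the only measured step, an at least 16-fold higher number from compound 1 to compound 2 (1.22 log units; beyond the scatter), changes the group on the carbonyl carbon rather than the aryl on the hydrazone carbon, so it does not bear on this change. Among the compounds with values here, no measured step speaks to moving the trifluoromethyl on that aryl, and the step expected here, a 1.2-fold lower number from compound 3 to compound 4 (0.09 log units; within the scatter), is therefore none beyond the scatter. Compound 4 is expected to give about 10 ug/mL, within 3 ug/mL to 40 ug/mL.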

Compound 4, half-maximal inhibitory concentration: 4.98 ug/mL
Compound 4: the middle estimate sits 2.0-fold (0.30 log units) above what was measured; measured number inside the range.
By their numbers in this assay, from the lowest: compounds 4 and 1 (each within the scatter of the next); then compound 3. At a limit, above all of these: compound 2.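

On the carbon with a double bond to nitrogen, 4-(trifluoromethyl)phenyl in place of 2-(trifluoromethyl)phenyl gives a 2.4-fold lower number from compound 3 to compound 4 (0.39 log units; beyond the scatter), so the place of the trifluoromethyl on this aryl does change the read-out. With that aryl kept, 2-fluorophenyl in place of 3,4-difluorophenyl on the carbonyl carbon gives a 1.2-fold lower number from compound 1 to compound 4 (0.08 log units; within the scatter), which does not separate these two groups, while 2-fluorophenyl in place of 4-(trifluoromethyl)phenyl there gives an at least 20-fold lower number from compound 2 to compound 4 (1.30 log units; beyond the scatter). That last step starts from a limit of the assay, not a number: the limit of > 100 ug/mL in this assay, at which 1 of the 4 values shown sits.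

The compounds shown leave open what a nitrile or a carboxylic acid would give in place of the trifluoromethyl on this aryl. They also do not tell why the two placements differ.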